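This account rests on a few compounds, and the source may have more. Where it says the series, first, only, none or still open, it means among the compounds named here.

Measured compounds:
Compound 1, `C=CCn1c(=O)/c(=C\c2cc(F)ccc2C)[nH]c(=O)/c1=C\c1ccccc1OC`: 3100 nM
Compound 2, `COc1ccccc1/C=c1\c(=O)[nH]/c(=C/c2ccccc2Cl)c(=O)n1C`: 200 nM
Compound 3, `COc1ccccc1/C=c1/[nH]c(=O)/c(=C\c2nc[nH]c2C(C)(C)C)[nH]c1=O`: 100 nM

In a functional assay on MCF7 cells (Homo sapiens) for cytotoxicity, read by CCK-8 assay, with a stated time of 72 h (a higher number here means a weaker inhibitor, a lower number a stronger inhibitor), compound 1 gives 3100 nM, the highest of the three numbers. Compound 2 gives 200 nM and compound 3 gives 100 nM; both gaps to compound 1 lie beyond the scatter, so compound 1 is the weakest of the measured set. Among the compounds with values here, compounds 2 and 3 differ from compound 1 in more than one place, so no measured pair isolates a single structural change, and nothing measured speaks to the exchange considered next.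

Compound 4, `C=CCn1c(=O)/c(=C\c2cc(Br)ccc2F)[nH]c(=O)/c1=C\c1ccccc1OC`, is not yet measured. It differs from compound 1 in one place: 5-bromo-2-fluorophenyl in place of 5-fluoro-2-methylphenyl on a double-bonded chain carbon bound to an aromatic carbon. Within the data shown here, with no measured pair of this kind on the shared core, the expectation rests on compound 1 alone and stays open in direction. The expected step is a 1.6-fold lower number from compound 1 to compound 4 (0.19 log units; within the scatter), a modest move that could fall either way or within the scatter. Compound 4 is expected to give 2000 nM, with a range from 500 nM to 8000 nM.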

Compound 4, half-maximal inhibitory concentration: 28100 nM
Compound 4: the middle estimate sits 14-fold (1.15 log units) below what was measured; measured number above the stated range.
By their numbers in this assay, from the lowest: compounds 3 and 2 (each within the scatter of the next); then compound 1; then compound 4.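

In this assay, placing 5-bromo-2-fluorophenyl in place of 5-fluoro-2-methylphenyl on a double-bonded chain carbon bound to an aromatic carbon gives a 9.1-fold higher number from compound 1 to compound 4 (0.96 log units; beyond the scatter) and shows that this position on the shared core is sensitive to the substituents on the phenyl ring. The step appears although both groups have the same heavy-atom count and neither has a hydrogen-bond donor or acceptor, so those counts do not separate the two compounds. No measurement shown here explains the step.

Both ring substituents change together in this single pair, leaving the separate contributions of the bromine and of fluorine in place of methyl unresolved. As far as these compounds go, whether an amine or a carboxylic acid on this phenyl ring would retain the activity of compound 1 also remains open.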